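The source may report more compounds than this note shows. Statements on the series, on what has been measured and on what is new or still open speak of the compounds shown alone.

Compound 1 `COc1ccc(OCCOCCNC2CCCC2)cc1`: 99100 nM
Compound 2 `Cc1ccc(COc2ccc(OCCOCCNC3CCCC3)cc2)cc1`: 17200 nM

In a functional assay on SK-OV-3 cells (Homo sapiens) for inhibition, read by CCK-8 assay, with a stated time of 70 h (on this read-out lower numbers stand for stronger inhibition and higher numbers for weaker inhibition), compound 2 holds the lower of the two numbers, at 17200 nM. For the measured compounds named here, only one measured step bears on what comes next: a 5.8-fold lower number from compound 1 to compound 2 (0.76 log units; beyond the scatter). That modest step put a 4-methylphenyl in place of hydrogen on a saturated chain carbon bound to an oxygen on an aromatic ring.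

Compound 3 `O=[N+]([O-])c1cccc(COc2ccc(OCCOCCNC3CCCC3)cc2)c1` alters exactly that added group, with 3-nitrophenyl in place of 4-methylphenyl on a saturated chain carbon bound to an oxygen on an aromatic ring. An aromatic ring remains at the same place, so this is a swap of one ring group for another, not a removal. Going by the values given here, no measured step shows such a swap, which leaves the direction open. Among the compounds with values here, the change in this assay is therefore expected to be smaller than the single measured step, and probably no larger than the scatter.

The expected change is a 1.1-fold lower number from compound 2 to compound 3 (0.03 log units; within the scatter), and this estimate carries no firm direction. For compound 3 the estimated value is 16000 nM, with an expected range of 5500 nM to 45000 nM.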

Compound 3, half-maximal inhibitory concentration: 15400 nM
Compound 3: middle estimate off by 1.0-fold (0.02 log units), on the high side, and the stated range covers the measured number.
By their numbers in this assay, from the lowest: compounds 3 and 2 (each within the scatter of the next); then compound 1.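

In this assay, the swap at this position gives a 1.1-fold lower number from compound 2 to compound 3 (0.05 log units; within the scatter), which is within the scatter, so 4-methylphenyl and 3-nitrophenyl cannot be told apart here, even though the entering group adds nitrogen and oxygen atoms and hydrogen-bond acceptors that the leaving group lacks. Set against hydrogen on the same carbon, 3-nitrophenyl gives a 6.4-fold lower number from compound 1 to compound 3 (0.81 log units; beyond the scatter), so two differently substituted aromatic rings now both stand clear of compound 1, and in these three compounds the step tracks the presence of a ring at this carbon rather than what that ring carries. Nothing available explains why the two ring groups read alike in this assay.

The compounds shown leave open whether an aromatic ring is needed at all, which a saturated ring such as cyclohexyl at the same carbon would test. They also leave open how much the identity and place of the ring's substituent matter, since this swap changes both at once; 4-nitrophenyl would separate the two, and a phenyl ring carrying an amine or a carboxylic acid would widen the range of groups tested.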